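A few compounds are considered here, and "the series" means these few. Any claim that something is new, unique, unknown or untested is made for them only; others in the source may bear on it.

Measured compounds in an ADME assay on Vero cells (Chlorocebus sabaeus) for cytotoxicity, with a stated time of 3 days; on this read-out higher numbers stand for lower toxicity in this test and lower numbers for higher toxicity in this test:
- compound 1 `COc1nc(ONC(=O)OCc2ccccc2)nc2c1ncn2[C@@H]1O[C@H](CO)[C@@H](O)[C@@]1(C)O`: only a limit, > 100000 nM
- compound 2 `COc1nc(OC)c2ncn([C@@H]3O[C@H](CO)[C@@H](O)[C@@]3(C)O)c2n1`: only a limit, > 100000 nM

Compound 1 stands at the assay limit in this assay, not at a number. Compound 2 likewise gives only a limit in this assay. Among the compounds with values here, the single measured step, a step that the two limits leave unreadable from compound 1 to compound 2, is thus unreadable; the only evidence is the limit of > 100000 nM in this assay, at which 2 of the 2 values shown sit. Compound 3 `C[C@@]1(O)[C@H](O)[C@@H](CO)O[C@H]1n1cnc2c(N)nc(ONC(=O)OCc3ccccc3)nc21` differs from compound 1 by amino in place of methoxy on an aromatic carbon. Within the data shown here, no measured step bears on this change, and compound 1 is known only as a limit, so no step beyond the scatter in either direction is expected in this assay. Compound 3 is expected at 150000 nM (range 50000 nM to 500000 nM), meaning a step that the limit leaves unreadable from compound 1 to compound 3, most probably reported again only as a limit.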

Compound 3, half-maximal cytotoxic concentration: > 100000 nM
Compound 3 was reported as a limit; the forecaster's own chance of this, stated with the estimate: 85%; the middle value is on the limit's open side.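

In this assay, within the data shown here, compound 3 gives > 100000 nM as a limit, not a number, and compound 1 is also known only as a limit, so no step between them can be read. Whether amino in place of methoxy on this aromatic carbon changes cytotoxicity stays open, with only this to go on: the limit of > 100000 nM in this assay, at which 3 of the 3 values shown sit.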